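A few compounds are considered here, and "the series" means these few. Any claim that something is new, unique, unknown or untested is made for them only; others in the source may bear on it.

Compound 1 `C/C(=C\c1cc(-c2ccc(C)cc2)cs1)C(N)=O`: in a functional assay on HO8910 cells (Homo sapiens) for cytotoxicity, read by CCK-8 assay, with a stated time of 24 h (on this read-out lower numbers stand for stronger inhibition and higher numbers for weaker inhibition), compound 1 gives > 50000 nM, which is a limit of the assay.
Compound 2 `C/C(=C\c1cc(-c2ccc(F)cc2)cs1)C(N)=O`: compound 2 gives > 50000 nM, also a limit.
Compound 3 `C/C(=C\c1cc(-c2ccc([N+](=O)[O-])cc2)cs1)C(N)=O`: compound 3 gives 2380 nM.

For the measured compounds named here, compound 3 therefore holds the only real number among the three; the other two sit at the limit of > 50000 nM in this assay, at which 2 of the 3 values shown sit. Compound 4 `COc1ccc(-c2csc(/C=C(\C)C(N)=O)c2)cc1` differs from compound 3 by methoxy in place of nitro on an aromatic carbon. Going by the values given here, no measured step swaps nitro for methoxy directly, but two steps lead into the nitro compound: an at least 21-fold lower number from compound 1 to compound 3 (1.32 log units; beyond the scatter) and an at least 21-fold lower number from compound 2 to compound 3 (1.32 log units; beyond the scatter). Both arrive at the nitro group from another substituent with a large drop, so removing the nitro is expected to undo most of that gain, a large step upward, an 11-fold higher number from compound 3 to compound 4 (1.02 log units; beyond the scatter). Compound 4 is estimated at 25000 nM, within a range from 4000 nM to 50000 nM, with a fair chance that only a limit is reported.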

Compound 4, half-maximal inhibitory concentration: > 50000 nM
Compound 4 ended at the assay's limit (the forecaster's own chance of this, stated with the estimate: 50%); at least 2.0-fold (0.30 log units) between middle value and limit.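

In this assay, methoxy in place of nitro on this aromatic carbon, para to a large group, gives an at least 21-fold higher number from compound 3 to compound 4 (1.32 log units; beyond the scatter). Methoxy also contains oxygen, yet nitro remains the only one of the four groups here with a real number, so oxygen in the group is not enough for a readable value. The steps from compound 1 and compound 2 to compound 4 cannot be read, because both ends of each sit at a limit: the limit of > 50000 nM in this assay, at which 3 of the 4 values shown sit.

On these data alone, whether an amine, a nitrile or a carboxylic acid at this position would also give a real number stays open. As far as these compounds go, the order among compound 1, compound 2 and compound 4 also stays open.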